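From 3-fluorophenyl to 4-fluorophenyl: what to expect

The source may report more compounds than this note shows. Statements on the series, on what has been measured and on what is new or still open speak of the compounds shown alone.

- Compound 1 `Cc1cccc(-n2cc(-c3ccc(/C=C4\C(=O)Nc5ccc(F)cc54)cc3)nn2)c1`: 9880 nM
- Compound 2 `O=C1Nc2ccc(F)cc2/C1=C/c1ccc(-c2cn(-c3cccc(F)c3)nn2)cc1`: 17300 nM

In an ADME assay on HUVEC cells (Homo sapiens) for inhibition, read by CCK-8 assay, with a stated time of 24 h, in the presence of a further agent that is not named here (on this read-out lower numbers stand for stronger inhibition and higher numbers for weaker inhibition), compound 2 gives 17300 nM, while compound 1 gives 9880 nM. These two numbers lie within the usual scatter of repeated measurements, so neither compound can be called the stronger inhibitor.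

The next compound, compound 3 `O=C1Nc2ccc(F)cc2/C1=C/c1ccc(-c2cn(-c3ccc(F)cc3)nn2)cc1`, has not yet been measured. It contains the same atoms as compound 2, joined differently: 4-fluorophenyl in place of 3-fluorophenyl on an aromatic nitrogen. Put simply, 4-fluorophenyl stands in place of 3-fluorophenyl on an aromatic nitrogen, and the shared core stays the same.

For the measured compounds named here, only one measured step offers any guide. This is a 1.8-fold higher number from compound 1 to compound 2 (0.24 log units; within the scatter), which came from fluoro in place of methyl on an aromatic carbon. Going by the values given here, that is a different kind of change, and no measured pair shows a swap between 3-fluorophenyl and 4-fluorophenyl. Among the compounds with values here, with only that small step to go on, no change beyond the scatter is expected in this assay. The estimated step is a 1.2-fold lower number from compound 2 to compound 3 (0.06 log units; within the scatter). For compound 3 the expected value is 15000 nM, with an estimated range from 7000 nM to 32000 nM.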

Compound 3, half-maximal inhibitory concentration: > 20000 nM
Compound 3 gave a limit, no number; the forecaster's own chance of this, stated with the estimate: 10%; middle value at least 1.3-fold (0.12 log units) away from the limit.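

In this assay compound 3 gives a limit and not a number: the limit of > 20000 nM in this assay, at which 1 of the 3 values shown sits. The first direct test of 4-fluorophenyl in place of 3-fluorophenyl on an aromatic nitrogen gives an at least 1.1-fold higher number from compound 2 to compound 3 (0.06 log units; that floor lies within the scatter), so the two isomers, which have the same atoms joined differently, show no sign that 4-fluorophenyl brings stronger inhibition, but this floor does not show whether the true gap is within the scatter or beyond it. The comparison with the methyl compound gives an at least 2.0-fold higher number from compound 1 to compound 3 (0.30 log units; that floor lies within the scatter), and this too is only a floor, so 4-fluorophenyl in place of 3-methylphenyl leaves the size of the change unsettled, while still pointing the same way as the swap of the fluoro position.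

The compounds shown leave open how far beyond the limit the true value of compound 3 lies, so the effect of this swap has no measured size. Going by these compounds, they also carry only methyl or fluoro on this phenyl ring, so it remains unknown what an amine, a carboxylic acid or a longer chain in that place would do in this assay.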